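Nitrooxyacetyl ester in place of a pyrazole ester

The source may hold more compounds than are shown below. What is called first, only, known or untested is meant among the compounds shown, and "the series" means these compounds.

Measured compounds:
compound 1 `CC(=O)Oc1ccccc1C(=O)O[C@H]1CO[C@H]2[C@@H]1OC[C@H]2OC(=O)c1snnc1C`: 0.0642 h
compound 2 `CC(=O)Oc1ccccc1C(=O)O[C@H]1CO[C@H]2[C@@H]1OC[C@H]2OC(=O)c1ccnn1C`: 0.0963 h
compound 3 `CC(=O)Oc1ccccc1C(=O)O[C@H]1CO[C@H]2[C@@H]1OC[C@H]2O[N+](=O)[O-]`: 0.0144 h

In an ADME assay on a cell-free system (plasma, Homo sapiens) for metabolic stability, with Plasma (Rattus norvegicus) as the target, read by HPLC, at pH 7.4 (a higher number here means that the compound lasts longer, a lower number that the compound disappears faster), compound 2 gives 0.0963 h. Its step from compound 1, a 1.5-fold higher number from compound 1 to compound 2 (0.18 log units; within the scatter), sits within the scatter, whereas a 6.7-fold lower number from compound 2 to compound 3 (0.83 log units; beyond the scatter) separates it clearly from compound 3. Compound 4 `CC(=O)Oc1ccccc1C(=O)O[C@H]1CO[C@H]2[C@@H]1OC[C@H]2OC(=O)CO[N+](=O)[O-]` is not yet measured; it differs from compound 2 by (nitrooxy)methyl in place of 1-methyl-1H-pyrazol-5-yl on a carbonyl carbon. The step that bears most on it is a 6.7-fold lower number from compound 2 to compound 3 (0.83 log units; beyond the scatter), where the acyl group at this oxygen was removed altogether; a 4.5-fold lower number from compound 1 to compound 3 (0.65 log units; beyond the scatter) points the same way. Compound 4 keeps a carbonyl here but carries the nitro oxygen on its chain, so a smaller drop than that to compound 3 is expected, a 1.9-fold lower number from compound 2 to compound 4 (0.28 log units; within the scatter). Compound 4 is therefore estimated at 0.05 h, within 0.02 h to 0.12 h.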

Compound 4, half-life: 0.06 h
Beside the measured number, compound 4's estimate is 1.2-fold (0.08 log units) below it; low and high end bracket the measured number.
By their numbers in this assay, from the lowest: compound 3; then compounds 4, 1 and 2 (each within the scatter of the next).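

In this assay, the step of a 4.2-fold higher number from compound 3 to compound 4 (0.62 log units; beyond the scatter) shows that placing a carbonyl between this oxygen and the nitrooxy unit separates the result from that of the nitro group on the oxygen. An aromatic ring on the carbonyl carbon is not required to hold this level, as the open-chain (nitrooxy)methyl ester matches both ring esters in a 1.6-fold lower number from compound 2 to compound 4 (0.21 log units; within the scatter) and a 1.1-fold lower number from compound 1 to compound 4 (0.03 log units; within the scatter). Nothing available explains these differences. Going by these compounds, whether a longer nitrooxy chain, or a plain methyl on the carbonyl carbon, would stay at this level remains open.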